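Aryl exchange at the assay limit

The source may report more compounds than this note shows. Statements on the series, on what has been measured and on what is new or still open speak of the compounds shown alone.

In an ADME assay on microsomes from liver (Rattus norvegicus) for metabolic stability (on this read-out higher numbers stand for a longer-lived compound and lower numbers for a shorter-lived compound), compound 1 `Nc1nc(NCCNc2ncc(-c3ncc[nH]3)c(-c3ccc(F)cc3Cl)n2)ccc1[N+](=O)[O-]` gives > 0.5 h, which is a limit and not a number. Compound 2 `Cc1ccc(-c2nc(NCCNc3ccc([N+](=O)[O-])c(N)n3)ncc2-c2ncc[nH]2)c(Br)c1` gives > 0.5 h, likewise a limit. Compound 3 `COc1cc(Cl)ccc1-c1nc(NCCNc2ccc([N+](=O)[O-])c(N)n2)ncc1-c1ncc[nH]1` differs from it by 4-chloro-2-methoxyphenyl in place of 2-bromo-4-methylphenyl on an aromatic carbon. Going by the values given here, the one measured step that bears on this, a step that the two limits leave unreadable from compound 1 to compound 2, is also an aryl exchange, but it has no readable size. Among the compounds with values here, the only evidence is the limit of > 0.5 h in this assay, at which 2 of the 2 values shown sit. No change beyond the scatter is therefore expected in this assay, and no direction can be foreseen. The expected step is a step that the limit leaves unreadable from compound 2 to compound 3. For compound 3 the estimated half-life is 0.7 h, expected between 0.35 h and 1.4 h.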

Compound 3, half-life: > 0.5 h
Compound 3 gave a limit, no number; the forecaster's own chance of this, stated with the estimate: 75%; the middle value is on the limit's open side.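

Going by these compounds alone, no step among compound 1, compound 2 and compound 3 can be read in this assay, as all three values are limits, not numbers. As far as these compounds go, the actual half-life of each compound, and whether the aryl exchanges change it, remain open.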